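A few compounds are considered here, and "the series" means these few. Any claim that something is new, unique, unknown or untested is made for them only; others in the source may bear on it.

Measured compounds:
compound 1, `Cc1cccc(-n2cc(-c3ccc(/C=C4\C(=O)Nc5ccccc54)cc3)nn2)c1`: 3940 nM
compound 2, `N#Cc1ccccc1-n1cc(-c2ccc(/C=C3\C(=O)Nc4ccccc43)cc2)nn1`: 14400 nM

In a functional assay on HT-29 cells (Homo sapiens) for inhibition, read by CCK-8 assay, with a stated time of 24 h (on this read-out higher numbers stand for weaker inhibition and lower numbers for stronger inhibition), compound 1 gives 3940 nM, the lowest of the two numbers; the nearest is compound 2, which in this assay gives 14400 nM. Among the measured compounds shown here, the one measured step, a 3.7-fold higher number from compound 1 to compound 2 (0.56 log units; beyond the scatter), came from 2-cyanophenyl in place of 3-methylphenyl on an aromatic nitrogen. Compound 3, `O=C1Nc2ccccc2/C1=C/c1ccc(-c2cn(-c3ccc(Cl)c(C(F)(F)F)c3)nn2)cc1`, differs from compound 1 in one place: 4-chloro-3-(trifluoromethyl)phenyl in place of 3-methylphenyl on an aromatic nitrogen. For the measured compounds named here, the measured step concerns a different entering group at the same aromatic nitrogen and so gives no direction for this change; it shows only that a change at this position can move the number beyond the scatter. With nothing closer to go on, the expected step is a 1.3-fold lower number from compound 1 to compound 3 (0.12 log units; within the scatter), which is within the scatter. Compound 3 is therefore estimated at 3000 nM in this assay, with a range from 800 nM to 12000 nM.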

Compound 3, half-maximal inhibitory concentration: 9670 nM
The estimate for compound 3 lay 3.2-fold (0.51 log units) below the measured number; the measured number falls inside the stated range.
By their numbers in this assay, from the lowest: compound 1; then compounds 3 and 2 (each within the scatter of the next).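

In this assay, a second replacement at this aromatic nitrogen, 4-chloro-3-(trifluoromethyl)phenyl for 3-methylphenyl, gives a 2.5-fold higher number from compound 1 to compound 3 (0.39 log units; beyond the scatter) and so moves the number the same way as the 2-cyanophenyl change. Compound 1 therefore holds the lowest number of the three, while the comparison of the two replacements gives a 1.5-fold lower number from compound 2 to compound 3 (0.17 log units; within the scatter) and separates neither from the other. No measurement here bears on why these replacements differ from 3-methylphenyl.

The compounds shown leave open whether any group at this nitrogen can bring the number lower than compound 1 does. They also leave open how a phenyl ring bearing an amine or a carboxylic acid, or a longer chain in place of the ring, would read.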